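Methyl-for-hydrogen step on an aryl amide series

A few compounds are considered here, and "the series" means these few. Any claim that something is new, unique, unknown or untested is made for them only; others in the source may bear on it.

Measured compounds:
compound 1, `COc1cc2c(Oc3ccc(NC(=O)c4cc(-c5ccccc5)ccn4)cc3F)ccnc2cc1OCCCN1CCCC1`, 1010 nM
compound 2, `COc1cc2c(Oc3ccc(NC(=O)c4cc(-c5ccc(C)cc5)ccn4)cc3F)ccnc2cc1OCCCN1CCCC1`, 560 nM
compound 3, `COc1cc2c(Oc3ccc(NC(=O)c4nccc(-c5ccccc5)n4)cc3F)ccnc2cc1OCCCN1CCCCC1`, "not determined" (no result reported) in a functional assay on U-87MG ATCC cells (Homo sapiens) for cytotoxicity, read by MTT assay, with a stated time of 72 h; a higher number here means a weaker inhibitor, a lower number a stronger inhibitor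

Compound 1 and compound 2 share a core and differ only by methyl in place of hydrogen on an aromatic carbon. That change gave a 1.8-fold lower number from compound 1 to compound 2 (0.26 log units; within the scatter). Compound 3 carries a different core; the difference between the two cores is not broken down here, and for compound 3 the entry in this assay reads "not determined" (no result reported). Compound 4, `COc1cc2c(Oc3ccc(NC(=O)c4nccc(-c5ccc(C)cc5)n4)cc3F)ccnc2cc1OCCCN1CCCCC1`, is unmeasured and differs from compound 3 by methyl in place of hydrogen on an aromatic carbon, the same change as that from compound 1 to compound 2, at the same kind of place. On these data alone, with no value for compound 3, the expectation for compound 4 rests only on compound 1 at 1010 nM and compound 2 at 560 nM; on that basis compound 4 is estimated at 650 nM in this assay, with wide uncertainty because the core of compound 3 is untested.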

Compound 4, half-maximal inhibitory concentration: 1140 nM
For compound 4 the middle estimate is 1.8-fold (0.24 log units) below the measured one, and the stated range covers the measured number.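

Among these compounds, compound 3 reads "not determined" (no result reported) in this assay and compound 4 reads 1140 nM so no step between them can be read. On these data alone, whether phenyl to 4-methylphenyl acts on the core of compound 3 as on the core of compound 1 stays open. No evidence shown bears on these results.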